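The source may report more compounds than this note shows. Statements on the series, on what has been measured and on what is new or still open speak of the compounds shown alone.

Compounds measured so far:
compound 1 `O=C(C1CCN(S(=O)(=O)c2ccc3[nH]ncc3c2)CC1)N(Cc1ccccc1C(F)(F)F)C1CC1`: "not determined" (no result reported)
compound 2 `CCC(C)N(Cc1ccccc1C(F)(F)F)C(=O)C1CCN(S(=O)(=O)c2ccc3[nH]ncc3c2)CC1`: 100%

Among the compounds with values here, in a functional assay on CHO cells for positive allosteric modulation of muscarinic acetylcholine receptor M5 (Homo sapiens), read by calcium flux (on this read-out higher numbers stand for larger maximal responses and lower numbers for smaller maximal responses), compound 2 gives 100%, the only number in hand, since compound 1 carries no result. Compound 3 `O=C(C1CCN(S(=O)(=O)c2ccc3[nH]ncc3c2)CC1)N(Cc1ccccc1C(F)(F)F)CC1CCC1` is the next candidate. Its change from compound 2 is cyclobutylmethyl in place of sec-butyl on an amide-type nitrogen. Within the data shown here, both groups are small saturated carbon pieces of similar size, and with only one measured value no trend can be drawn, so the step is expected to stay within the usual scatter, a number 5 percentage points lower from compound 2 to compound 3 (within the scatter). On that basis compound 3 is estimated at 95%, with a range from 70% to 115%.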

Compound 3, largest response reached (reported as percent of maximum), in percent of the reference or control that the assay uses: 103%
Estimate against measurement, compound 3: 8 percentage points below; the range from low to high includes it.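

In this assay the change to cyclobutylmethyl in place of sec-butyl on the amide-type nitrogen gives a number 3 percentage points higher from compound 2 to compound 3 (within the scatter) and so stays within the scatter. This nitrogen therefore holds a group with a four-membered carbon ring as well as an open branched one, with no real change in maximal response. No measurement here explains this result.

Compound 1 has no result, so its cyclopropyl group offers no comparison. As far as these compounds go, whether a longer chain such as n-hexyl, or a group carrying an amine or a carboxylic acid, would keep this response remains open.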